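Swapping the fluorinated benzyl arm for a pyrimidinylmethyl arm

This account rests on a few compounds, and the source may have more. Where it says the series, first, only, none or still open, it means among the compounds named here.

Of the compounds shown here, three sharing one core have been measured in a physicochemical assay for lipophilicity, measured as octanol-water partition, at pH 7.4; a higher number here means a more lipophilic compound, a lower number a more polar compound. Compound 1 `Fc1ccccc1Cc1nc(-c2nc(C(F)(F)F)n[nH]2)n2ccccc12` sits highest of the three at 3.8. Compound 2 `Fc1ccccc1Cc1nc(-c2ncn[nH]2)n2ccccc12` gives 3.3, and compound 3 `NC(=O)c1n[nH]c(-c2nc(Cc3ccccc3F)c3ccccn23)n1` gives 2.8. The steps among them all concern the same aromatic carbon: a number 0.50 log units lower from compound 1 to compound 2 (beyond the scatter), a number 1.00 log units lower from compound 1 to compound 3 (beyond the scatter) and a number 0.50 log units lower from compound 2 to compound 3 (beyond the scatter).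

Compound 4 `FC(F)(F)c1n[nH]c(-c2nc(Cc3cncnc3)c3ccccn23)n1` has not yet been measured in this assay. It differs from compound 1 at a different place altogether: pyrimidin-5-yl in place of 2-fluorophenyl on a saturated chain carbon bound to an aromatic carbon. Going by the values given here, no measured step touches this position, so the three known steps give no direct guide; each of them replaced one group for another on an aromatic carbon, leaving the 2-fluorobenzyl arm untouched in every measured compound.

The expectation for compound 4 therefore rests on the change itself as counted: a carbon-only ring with one fluorine leaves, and a ring with two hetero atoms and two hydrogen-bond acceptors enters. On that basis compound 4 is expected to come out well below compound 1, with a step of a number 1.90 log units lower from compound 1 to compound 4 (beyond the scatter), a larger move than any of the three measured steps. Compound 4 is estimated at 1.9, with a range from 1.3 to 2.5.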

Compound 4, distribution coefficient: 1.8
Beside the measured number, compound 4's estimate is 0.10 log units above it, and the stated range covers the measured number.
By their numbers in this assay, from the lowest: compound 4; then compound 3; then compound 2; then compound 1.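

The 2-fluorobenzyl arm stayed fixed in compound 1, compound 2 and compound 3, so those compounds could not show whether this position matters in this assay. Replacing 2-fluorophenyl with pyrimidin-5-yl on a saturated chain carbon bound to an aromatic carbon, with trifluoromethyl kept in place, gives a number 2.00 log units lower from compound 1 to compound 4 (beyond the scatter) and so shows that this position can carry a large change, larger in size than the biggest change at the aromatic carbon, a number 1.00 log units lower from compound 1 to compound 3 (beyond the scatter). The compounds show the size of this step, but no available evidence explains why this exchange produces it.

Going by these compounds, what remains open is how the step divides between losing the fluorine and bringing in the two ring nitrogens, a question that a plain phenyl or a pyridin-3-yl group on the same chain carbon could help to separate. On these data alone, it is also open whether pyrimidin-5-yl would give a step of similar size with hydrogen or carbamoyl in place of trifluoromethyl, and how a longer chain between the core and the ring would behave.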